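A few compounds are considered here, and "the series" means these few. Any claim that something is new, unique, unknown or untested is made for them only; others in the source may bear on it.

Measured so far in a functional assay on HL-60 cells (Homo sapiens) for cytotoxicity, read by MTT assay; a higher number here means a weaker inhibitor, a lower number a stronger inhibitor:
- compound 1 `CC(NS(=O)(=O)c1ccc(Br)cc1)C1=CC(=O)c2c(O)ccc(O)c2C1=O`: 100 nM
- compound 2 `CC(=O)c1ccc(S(=O)(=O)NC(C)C2=CC(=O)c3c(O)ccc(O)c3C2=O)cc1`: 260 nM

Of these two compounds, compound 2 stands higher at 260 nM, so it is the weaker inhibitor in this assay. The next compound to be measured is compound 3 `CCOC(=O)c1ccc(S(=O)(=O)NC(C)C2=CC(=O)c3c(O)ccc(O)c3C2=O)cc1`. It differs from compound 2 in one place: ethoxy in place of methyl on a carbonyl carbon. The same difference, cut one bond further out, reads acetyl to ethoxycarbonyl.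

Among the compounds with values here, only one measured step bears on this change: a 2.6-fold higher number from compound 1 to compound 2 (0.41 log units; beyond the scatter). That step, acetyl in place of bromo on an aromatic carbon, is modest but beyond the scatter. Within the data shown here, it is a different exchange, and no measured compound carries ethoxycarbonyl, so the data give no firm direction. The expectation is therefore a small change, no larger than the modest step already seen and quite possibly within the scatter. The expected step is a 1.2-fold lower number from compound 2 to compound 3 (0.07 log units; within the scatter). For compound 3 the estimated value is 220 nM, with an expected range of 100 nM to 480 nM.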

Compound 3, half-maximal inhibitory concentration: 120 nM
Beside the measured number, compound 3's estimate is 1.8-fold (0.26 log units) above it; the range from low to high includes it.
By their numbers in this assay, from the lowest: compounds 1 and 3 (each within the scatter of the next); then compound 2.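

Within the data shown here, replacing methyl with ethoxy on a carbonyl carbon, which turns acetyl into ethoxycarbonyl, gives in this assay a 2.2-fold lower number from compound 2 to compound 3 (0.34 log units; beyond the scatter) and so shows for the first time that a change confined to this carbonyl carbon, with the aromatic carbon still bearing a carbonyl group, can move the number beyond the scatter, though only modestly. The exchange of bromo for ethoxycarbonyl gives a 1.2-fold higher number from compound 1 to compound 3 (0.08 log units; within the scatter) and leaves these two compounds indistinguishable here, so the earlier rise from bromo to acetyl does not extend to every carbonyl-bearing group at this place, with compound 3 going against any such reading. No measurement in hand offers an explanation for the difference between acetyl and ethoxycarbonyl.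

The compounds shown leave open whether a carboxylic acid, an amide or a longer chain on this carbonyl carbon would stay in the range of compound 3 or move back towards compound 2. They also leave open whether the gap between acetyl and ethoxycarbonyl would persist on the same scale with a different group in place of the ethyl of the ester, such as methyl or propyl.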